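The compounds below may be only part of what the source reports. "The series", "measured", "known", "first", "only" and "open" are said of these compounds alone.

Measured so far in a functional assay on the whole organism with Rattus norvegicus as the target, at a dose of 40 mg/kg by the intraperitoneal route; a lower number here means less inhibition, a higher number more inhibition at the dose given (going by the name of the read-out):
compound 1, `CCNc1c(C)nc2c(OCc3ccccc3)cccn12`, gives 95%
compound 2, `Cc1nc2c(OCc3ccccc3)cccn2c1NC(C)C`, gives 18%

Within the data shown here, compound 2 stands at the lowest of the two numbers measured; the only other compound, compound 1, sits far above it. Among the measured compounds shown here, the one measured step, a number 77 percentage points lower from compound 1 to compound 2 (beyond the scatter), came from a change on the group carried by the nitrogen on an aromatic ring, and it was large.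

Compound 3, `Cc1nc2c(OCc3ccccc3)cccn2c1NCc1ccccc1`, differs from compound 2 by benzyl in place of isopropyl on a nitrogen on an aromatic ring. Cut one bond further out, the change reads isopropylamino to benzylamino. For the measured compounds named here, the same part of the molecule that changed between compound 1 and compound 2 changes again here, so that step is the only guide, and it shows that this part of the molecule can swing the read-out over most of its range. Which direction a new group takes is not settled by one step, but since the isopropyl group is the one that coincided with the low number of compound 2, its removal is taken to favour a rise. Compound 3 is therefore expected to move by a number 37 percentage points higher from compound 2 to compound 3 (beyond the scatter), with wide uncertainty. The estimate for compound 3 is 55%, between 15% and 92%.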

Compound 3, a percentage reported as inhibition, in the whole organism at one dose (the size of the read-out at that dose, not a potency): 48%
Compound 3: the middle estimate sits 7 percentage points above what was measured; measured number inside the range.
By their numbers in this assay, from the lowest: compound 2; then compound 3; then compound 1.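

In this assay, benzyl in place of isopropyl on the nitrogen gives a number 30 percentage points higher from compound 2 to compound 3 (beyond the scatter), so this position accepts a group carrying a six-membered aromatic ring and the number still rises above that of compound 2. That gain does not restore the level of the ethyl compound, though: phenyl in place of methyl on the saturated chain carbon gives a number 47 percentage points lower from compound 1 to compound 3 (beyond the scatter), so among these three compounds the number does not simply follow the heavy-atom count of the group, with ethyl highest, isopropyl with 3 heavy atoms lowest and benzyl with 7 in the middle. Nothing available explains why the three groups fall in this order.

Open, from the compounds shown here alone, is whether a plain amino group, methylamino or a longer straight chain such as n-propyl or n-butyl on this nitrogen would match or pass compound 1. Also open, going by these compounds, is whether a methoxy group or a chlorine on the benzyl ring, or a phenethyl group in place of benzyl, would lift the number of compound 3 or lower it.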